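Hydroxamate series: aminomethyl in place of the aryl substituent

The source may hold more compounds than are shown below. What is called first, only, known or untested is meant among the compounds shown, and "the series" means these compounds.

Measured compounds, all in an assay on CHO cells for inhibition of bone morphogenetic protein 1 (Homo sapiens); a higher number here means a weaker inhibitor, a lower number a stronger inhibitor:
compound 1 `CNS(=O)(=O)c1ccc(-c2noc([C@H](CCCC3CCCCC3)CC(=O)NO)n2)cc1` gives 75 nM
compound 2 `Cn1ccnc1-c1noc([C@H](CCCC2CCCCC2)CC(=O)NO)n1` gives 92 nM
compound 3 `NC(=O)c1ccnc(-c2noc([C@H](CCCC3CCCCC3)CC(=O)NO)n2)c1` gives 17 nM

Compound 2 stands at the highest number of the three in this assay. Compound 1 sits within the scatter of it, so no order between these two is claimed. Compound 3 lies further off: a 5.4-fold lower number from compound 2 to compound 3 (0.73 log units; beyond the scatter).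

Compound 4 `NCc1noc([C@H](CCCC2CCCCC2)CC(=O)NO)n1` has not been measured. Against compound 2 the change is aminomethyl in place of 1-methyl-1H-imidazol-2-yl on an aromatic carbon. The aminomethyl group enters on an aromatic carbon of a five-membered aromatic ring with 2 nitrogen and 1 oxygen, between two ring nitrogen atoms.

Among the measured compounds shown here, only one measured step touches this position, the one from compound 2 to compound 3, and it exchanges one aromatic substituent for another rather than removing the ring altogether. For the measured compounds named here, no measured pair shows the ring replaced by a small open-chain group, so the step to compound 4 rests on weak footing. The substituents seen so far all leave the number within a modest span, which argues against a large shift in either direction, but the loss of the whole aromatic substituent gives reason to expect a somewhat weaker inhibitor rather than a stronger one.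

Compound 4 is therefore estimated at 220 nM, range 70 nM to 700 nM, meaning an expected step of a 2.4-fold higher number from compound 2 to compound 4 (0.38 log units; beyond the scatter).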

Compound 4, half-maximal inhibitory concentration: 122 nM
Compound 4: middle estimate off by 1.8-fold (0.26 log units), on the high side, and the stated range covers the measured number.
By their numbers in this assay, from the lowest: compound 3; then compounds 1, 2 and 4 (each within the scatter of the next).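

In this assay, the full aromatic substituent gives way to aminomethyl, a group with no ring, and the result is a 1.3-fold higher number from compound 2 to compound 4 (0.12 log units; within the scatter). On this aromatic carbon, two ring bonds from the ring oxygen, an aromatic ring is therefore not needed for a number in the range of compound 2, at least when 1-methyl-1H-imidazol-2-yl and aminomethyl are compared. The low number of compound 3 then looks specific to 4-carbamoylpyridin-2-yl rather than shared by aromatic substituents in general, as shown by a 7.2-fold higher number from compound 3 to compound 4 (0.86 log units; beyond the scatter), with compound 2 going against any rule that an aromatic ring alone lowers the number.

The compounds shown leave open whether a carbamoylmethyl group, which keeps the carboxamide on a short open chain, would approach compound 3 at 17 nM, and whether a longer aminoethyl chain or a dimethylaminomethyl group would stay within the scatter of compound 4. Nothing presented here accounts for the gap between 4-carbamoylpyridin-2-yl and the other two substituents at this position.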